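Thiophene in Place of Bromophenyl on the Ketone Carbonyl

A few compounds are considered here, and "the series" means these few. Any claim that something is new, unique, unknown or untested is made for them only; others in the source may bear on it.

Compound 1 `COc1ccc(C(=O)C2Sc3nnc(-c4cc(OC)c(OC)c(OC)c4)n3NC2c2ccco2)cc1`: in a functional assay on A549 cells (Homo sapiens) for cytotoxicity, read by MTT assay, with a stated time of 48 h (a lower number here means a stronger inhibitor, a higher number a weaker inhibitor), compound 1 gives > 100000 nM, which is a limit of the assay.
Compound 2 `COc1cc(-c2nnc3n2NC(c2ccco2)C(C(=O)C2CC2)S3)cc(OC)c1OC`: in this assay compound 2 gives > 100000 nM, again a limit of the assay.
Compound 3 `COc1cc(-c2nnc3n2NC(c2ccco2)C(C(=O)c2cccc(Br)c2)S3)cc(OC)c1OC`: in this assay compound 3 gives 36900 nM.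

Compound 3 is thus the only one of the three with a number in this assay; the other two sit at the limit of > 100000 nM in this assay, at which 2 of the 3 values shown sit. The steps leading to it are an at least 2.7-fold lower number from compound 1 to compound 3 (0.43 log units; beyond the scatter) and an at least 2.7-fold lower number from compound 2 to compound 3 (0.43 log units; beyond the scatter), both only readable as lower bounds, while a step that the two limits leave unreadable from compound 1 to compound 2 cannot be read at all.

Compound 4 `COc1cc(-c2nnc3n2NC(c2ccco2)C(C(=O)c2cccs2)S3)cc(OC)c1OC` differs from compound 3 in one place: thiophen-2-yl in place of 3-bromophenyl on a carbonyl carbon. The two steps that bear on this position show only that the 3-bromophenyl ketone gave a number where the 4-methoxyphenyl and cyclopropyl ketones gave none. Nothing measured shows how a smaller heteroaromatic ring on that carbonyl behaves. With a weak number as the starting point, compound 4 is expected to lose some of that activity and may return to the limit, an estimated 1.8-fold higher number from compound 3 to compound 4 (0.25 log units; within the scatter). Compound 4 is therefore estimated at 65000 nM, between 25000 nM and 160000 nM.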

Compound 4, half-maximal inhibitory concentration: 78700 nM
Compound 4: middle estimate off by 1.2-fold (0.08 log units), on the low side; the range from low to high includes it.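

Compound 4 is the second ketone here to give a number in this assay, so a readable value on this carbonyl does not depend on the 3-bromophenyl group alone, and a five-membered sulfur-containing ring can also provide one. Even so, the exchange gives a 2.1-fold higher number from compound 3 to compound 4 (0.33 log units; beyond the scatter), which places the thiophen-2-yl ketone behind the 3-bromophenyl ketone and shows that this position responds to the choice of ring even within this weak range. Against the cyclopropyl and 4-methoxyphenyl ketones, the comparison yields only floors, an at least 1.2-fold lower number from compound 2 to compound 4 (0.10 log units; that floor lies within the scatter) and an at least 1.2-fold lower number from compound 1 to compound 4 (0.10 log units; that floor lies within the scatter), so compound 4 cannot be set clearly apart from either of these ketones, whose values are limits of the assay: the limit of > 100000 nM in this assay, at which 2 of the 4 values shown sit.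

The compounds shown leave open whether the bromine of compound 3 matters in itself, as a plain phenyl or a 3-chlorophenyl group on this carbonyl stands nowhere among them. They also leave open how a pyridin-3-yl ring, or a phenyl ring carrying an amine or a carboxylic acid, would behave at this position.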